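From a Cinnamate Ester to a Short Cinnamamide

The source may hold more compounds than are shown below. What is called first, only, known or untested is meant among the compounds shown, and "the series" means these compounds.

Of the compounds shown here, two on the shared core have been measured. Compound 1, `CCCCCCCCCCCCCCCCNC(=O)/C=C/c1ccccc1`, gives in a functional assay on the whole organism for inhibition, with Brassica rapa subsp. chinensis as the target, with a stated time of 3 days, tested at 100 ppm (on this read-out lower numbers stand for less inhibition of growth and higher numbers for more inhibition of growth at the one concentration tested), a value of 75%. Compound 2, `CCC(C)OC(=O)/C=C/c1ccccc1`, gives in this assay a value of 20%. Compound 2 thus stands lowest of the two numbers; its nearest neighbour is compound 1, whose number lies higher by a gap beyond the usual scatter.

Compound 3, `CCCNC(=O)/C=C/c1ccccc1`, is not yet measured. Compared with compound 2 it carries propylamino in place of sec-butoxy on a carbonyl carbon. Going by the values given here, no measured pair in the set differs in exactly this one place, so the size of this step is open. Among the compounds with values here, the only guide is that compound 1, with 75%, sits well above compound 2, yet compound 1 also bears a far longer chain on the carbonyl carbon, so the two changes cannot be told apart.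

The expected step from compound 2 to compound 3 is a number 20 percentage points higher from compound 2 to compound 3 (beyond the scatter), upward but of uncertain size. Compound 3 is therefore estimated at 40%, with a range from 15% to 70%.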

Compound 3, percent growth inhibition at one concentration: 63%
Estimate against measurement, compound 3: 23 percentage points below; the measured number falls inside the stated range.
By their numbers in this assay, from the lowest: compound 2; then compound 3; then compound 1.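

Going by these compounds alone, on this assay, placing propylamino in place of sec-butoxy on a carbonyl carbon gives a number 43 percentage points higher from compound 2 to compound 3 (beyond the scatter), the first single-place change that can be read in this set, and it shows that this position strongly affects the read-out. Within the data shown here, it also shows that a chain as long as the one in compound 1 is not required for a high number here: compound 3, with only a propylamino group, gives 63%, and compound 1 gives 75%. Nothing measured on these compounds explains why the swap has this effect, so the step stands as an observation only.

The swap alters the atom bound to the carbonyl carbon, oxygen in sec-butoxy and nitrogen in propylamino, and the attached carbon chain at the same time, so the compounds shown leave open how much of the step belongs to each part. A sec-butylamino group and a propoxy group at this carbonyl carbon would separate the two, and an octylamino group would show how the number behaves with a chain length between those of compound 3 and compound 1.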